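Aromatic nitrogen substituent changes in the amide acid series

The source may report more compounds than this note shows. Statements on the series, on what has been measured and on what is new or still open speak of the compounds shown alone.

Measured compounds:
Compound 1, `CCCCCn1ccc2cc(/C(C)=C/C(=O)Nc3ccccc3OCCCC(=O)O)ccc21`, gives 23 nM in an assay on Prostate gland for inhibition of steroid 5-alpha-reductase (Rattus norvegicus); on this read-out lower numbers stand for stronger inhibition and higher numbers for weaker inhibition.
Compound 2, `CCCCCC(CCCCC)n1ccc2cc(/C(C)=C/C(=O)Nc3ccccc3OCCCC(=O)O)ccc21`, gives 25 nM in this assay.
Compound 3, `C/C(=C\C(=O)Nc1ccccc1OCCCC(=O)O)c1ccc2c(ccn2Cc2ccccc2C)c1`, gives 69 nM in this assay.

Compound 3 stands at the highest of the three numbers; its nearest neighbour is compound 2, a 2.8-fold higher number from compound 2 to compound 3 (0.44 log units; beyond the scatter), and the widest gap is to compound 1, a 3.0-fold higher number from compound 1 to compound 3 (0.48 log units; beyond the scatter). Compound 4, `CCC(c1ccccc1)n1ccc2cc(/C(C)=C/C(=O)Nc3ccccc3OCCCC(=O)O)ccc21`, is not yet measured. The change from compound 3 to compound 4 is 1-phenylpropyl in place of 2-methylbenzyl on an aromatic nitrogen.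

Going by the values given here, two measured steps bear on this. The step of a 1.1-fold higher number from compound 1 to compound 2 (0.04 log units; within the scatter) shows that going from a straight chain to a branched chain on the aromatic nitrogen leaves the number unchanged. The step of a 2.8-fold higher number from compound 2 to compound 3 (0.44 log units; beyond the scatter) shows that replacing a branched chain with the 2-methylbenzyl group raises the number modestly. Compound 4 carries a branched group bearing a phenyl, so it sits between the cases of compound 2 and compound 3; a modest drop in the number from compound 3, partway back toward compound 2, is expected, with a real chance of no step beyond the scatter. The expected step is a 1.7-fold lower number from compound 3 to compound 4 (0.24 log units; within the scatter). For compound 4 the estimate in this assay is 40 nM, within 18 nM to 90 nM.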

Compound 4, half-maximal inhibitory concentration: 19 nM
The estimate for compound 4 lay 2.1-fold (0.32 log units) above the measured number; measured number inside the range.
By their numbers in this assay, from the lowest: compounds 4, 1 and 2 (each within the scatter of the next); then compound 3.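

In this assay the step to 1-phenylpropyl on the aromatic nitrogen (a 3.6-fold lower number from compound 3 to compound 4 (0.56 log units; beyond the scatter)) shows that a group carrying a phenyl ring at this place need not give the higher number seen with 2-methylbenzyl in compound 3. The phenyl-bearing group also stays level with both alkyl groups (a 1.3-fold lower number from compound 2 to compound 4 (0.12 log units; within the scatter); a 1.2-fold lower number from compound 1 to compound 4 (0.08 log units; within the scatter)), so this position accepts pentyl, 1-pentylhexyl and 1-phenylpropyl alike, with compound 3 as the one exception among the compounds shown. Nothing measured here accounts for the gap between the two phenyl-bearing groups.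

Still open, from the compounds shown here alone, is whether that gap follows the methyl on the ring of 2-methylbenzyl or the unbranched link to the nitrogen; plain benzyl and 1-phenylethyl would separate the two. An amine or a carboxylic acid on this substituent also remains untested in the compounds shown.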